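A few compounds are considered here, and "the series" means these few. Any claim that something is new, unique, unknown or untested is made for them only; others in the source may bear on it.

Working notes on the series. Compound 3 `COc1ccc(/C=C\C(=O)O)c(OCc2cn(-c3cccnc3Cl)nn2)c1CC=C(C)C` in a functional assay on NCI-H322 cells (Homo sapiens) for cytotoxicity, read by MTT assay, with a stated time of 24 h (a higher number here means a weaker inhibitor, a lower number a stronger inhibitor), gives 42200 nM. The only other number shown is for compound 2 `COc1ccc(/C=C\C(=O)O)c(OCc2cn(-c3cccc([N+](=O)[O-])c3)nn2)c1CC=C(C)C`, which in this assay gives 43200 nM; the step of a 1.0-fold lower number from compound 2 to compound 3 (0.01 log units; within the scatter) lies within the scatter, so the two compounds sit together and neither stands apart. Compound 1 `COc1ccc(-n2cc(COc3c(/C=C\C(=O)O)ccc(OC)c3CC=C(C)C)nn2)cc1` in this assay has "not determined" (no result reported). Compound 4 `COc1ccc(/C=C\C(=O)O)c(OCc2cn(-c3nc4ccccc4s3)nn2)c1CC=C(C)C` carries 1,3-benzothiazol-2-yl in place of 2-chloropyridin-3-yl on an aromatic nitrogen. Going by the values given here, the one measured step that bears on it, a 1.0-fold lower number from compound 2 to compound 3 (0.01 log units; within the scatter), is a swap of the group on the same aromatic nitrogen and was within the scatter; nothing measured speaks to a benzothiazolyl group itself. The expectation for compound 4 is therefore no step beyond the scatter, a 1.0-fold lower number from compound 3 to compound 4 (0.00 log units; within the scatter). Compound 4 is estimated at 42000 nM, within a range from 18000 nM to 95000 nM.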

Compound 4, half-maximal inhibitory concentration: 23000 nM
Estimate against measurement, compound 4: 1.8-fold (0.26 log units) above, within the range that was stated.
By their numbers in this assay, from the lowest: compounds 4, 3 and 2 (each within the scatter of the next).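

In this assay, the steps of a 1.8-fold lower number from compound 3 to compound 4 (0.26 log units; within the scatter) and a 1.9-fold lower number from compound 2 to compound 4 (0.27 log units; within the scatter) both stay within the scatter. On this aromatic nitrogen, the two-ring 1,3-benzothiazol-2-yl group, with its sulfur and larger heavy-atom count, therefore sits with the single-ring 2-chloropyridin-3-yl and 3-nitrophenyl groups, and no separation among these three aryl groups appears. No measurement at hand explains these values. Open, from the compounds shown here alone, is whether a group without an aromatic ring on this nitrogen, such as a benzyl group or a longer alkyl chain, would leave the number unchanged. Also open, going by these compounds, is whether an amine on the benzothiazole would do so.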